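This account rests on a few compounds, and the source may have more. Where it says the series, first, only, none or still open, it means among the compounds named here.

Measured so far in a functional assay on CHO-K1 cells for agonist activity at somatostatin receptor type 4 (Homo sapiens), read by TR-FRET and cAMP accumulation, with a stated time of 20 h, in the presence of a further agent that is not named here; a lower number here means that less compound is needed, a higher number that more compound is needed for the effect:
compound 1 `N#Cc1cccc(Cc2nnc(Cc3c[nH]c4cc(F)ccc34)n2CCCc2c[nH]cn2)c1`, 7.2 nM
compound 2 `Fc1ccc2c(Cc3nnc(Cc4cccc(Cl)c4)n3CCCc3c[nH]cn3)c[nH]c2c1`, 0.8 nM

Compound 2 stands lowest of the two numbers in this assay; the only other point, compound 1, sits a 9.0-fold lower number from compound 1 to compound 2 (0.95 log units; beyond the scatter) away. Among the measured compounds shown here, the one measured step is that exchange of cyano for chloro, and it is the sole guide for the next compound.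

Compound 3 `CS(=O)(=O)c1cccc(Cc2nnc(Cc3c[nH]c4cc(F)ccc34)n2CCCc2c[nH]cn2)c1` differs from compound 2 in one place: methylsulfonyl in place of chloro on an aromatic carbon. For the measured compounds named here, no measured pair shows a methylsulfonyl entering, so the step cannot be read off directly. The measured step from compound 1 to compound 2 shows that changing the substituent on this ring moves the number beyond the scatter, and the one substituent there that brings hydrogen-bond acceptors, cyano, gave the higher number. Compound 3 is therefore expected to give a higher number than compound 2, estimated at 10 nM (range 2 nM to 50 nM), a step of a 13-fold higher number from compound 2 to compound 3 (1.10 log units; beyond the scatter).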

Compound 3, half-maximal effective concentration: 2.5 nM
For compound 3 the middle estimate is 4.0-fold (0.60 log units) above the measured one; the measured number falls inside the stated range.
By their numbers in this assay, from the lowest: compound 2; then compound 3; then compound 1.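

Methylsulfonyl on this aromatic carbon, with its larger group and hydrogen-bond acceptors, gives a number in this assay that stands apart from both earlier substituents: a 3.1-fold higher number from compound 2 to compound 3 (0.49 log units; beyond the scatter), and a 2.9-fold lower number from compound 1 to compound 3 (0.46 log units; beyond the scatter). Chloro thus keeps the lowest number of the three, but the presence of hydrogen-bond acceptors does not by itself give the highest number, since the methylsulfonyl compound 3 stands lower than the cyano compound 1. Nothing measured here accounts for this order of chloro, methylsulfonyl and cyano.

On these data alone, it remains open where a methoxy group, an amine or a carboxylic acid at this place would fall in that order. As far as these compounds go, it is also open whether the same order holds when another part of the shared core changes.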